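Adding a Phenyl Ring Where Compound 2 Carries Hydrogen

The compounds below may be only part of what the source reports. "The series", "measured", "known", "first", "only" and "open" are said of these compounds alone.

Compound 2 `O=S(=O)(NCCCNCc1ccccc1)c1cc(C(F)(F)F)cc(C(F)(F)F)c1` gives the highest of the two numbers in a functional assay on BE(2)-C cells (Homo sapiens) for inhibition, read by MTT assay, with a stated time of 72 h (on this read-out higher numbers stand for weaker inhibition of growth and lower numbers for stronger inhibition of growth), at 12000 nM. Compound 1 `CC(C)(C)c1ccc(CNCCCNS(=O)(=O)c2cc(C(F)(F)F)cc(C(F)(F)F)c2)cc1` gives 2500 nM in this assay. Going by the values given here, the only measured step, a 4.8-fold higher number from compound 1 to compound 2 (0.68 log units; beyond the scatter), followed the loss of the tert-butyl group. Compound 3 `O=S(=O)(NCCCNCc1ccc(-c2ccccc2)cc1)c1cc(C(F)(F)F)cc(C(F)(F)F)c1` restores a large group at that carbon: phenyl in place of hydrogen on an aromatic carbon. Given that a 4.8-fold higher number from compound 1 to compound 2 (0.68 log units; beyond the scatter) accompanied removal of bulk there, replacing it with phenyl is expected to lower the number again, by roughly a 4.0-fold lower number from compound 2 to compound 3 (0.60 log units; beyond the scatter). Compound 3 is therefore estimated at 3000 nM, with a likely range of 900 nM to 10000 nM.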

Compound 3, concentration for 50% growth inhibition: 2600 nM
Compound 3: the middle estimate sits 1.2-fold (0.06 log units) above what was measured, and the stated range covers the measured number.
By their numbers in this assay, from the lowest: compounds 1 and 3 (each within the scatter of the next); then compound 2.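

In this assay, phenyl on this aromatic carbon gives a 4.6-fold lower number from compound 2 to compound 3 (0.66 log units; beyond the scatter) and so shows that the lower number is not tied to tert-butyl alone. Exchanging one large group for the other gives a 1.0-fold higher number from compound 1 to compound 3 (0.02 log units; within the scatter) and leaves the two groups indistinguishable on this read-out. Nothing available explains how either group acts on growth inhibition. Going by these compounds, it remains open whether methyl, methoxy or an amine at this carbon would track with hydrogen or with the two large groups, and whether a cyclohexyl ring would match phenyl.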